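A few compounds are considered here, and "the series" means these few. Any claim that something is new, unique, unknown or untested is made for them only; others in the source may bear on it.

Working notes on the series. Going by the values given here, compound 2 `CCCCCCCCCCCCCCCCO[C@@H]1O[C@H](CO)[C@@H](O)[C@H](O)[C@H]1O[C@@H]1O[C@@H](C)[C@H](OC(C)=O)[C@@H](OC(C)=O)[C@H]1OC(C)=O` is the reference point here: in an ADME assay on PBMC cells (Homo sapiens) for cytotoxicity, read by MTT assay, with a stated time of 72 h (on this read-out lower numbers stand for stronger inhibition and higher numbers for weaker inhibition), compound 2 gives 25500 nM, the only number measured so far. Compound 1 `CCCCCCCCCCCCCCCCO[C@@H]1O[C@H](CO)[C@@H](O)[C@H](O)[C@H]1O[C@@H]1O[C@@H](C)[C@H](OC(C)=O)[C@@H](OC(C)=O)[C@H]1O` differs from compound 2 by one acetyl group, and in this assay compound 1 gives only the limit > 39400 nM, not a number. Among the compounds with values here, the one measured step is an at least 1.5-fold lower number from compound 1 to compound 2 (0.18 log units; that floor lies within the scatter), and it runs toward a lower number when acetyl replaces hydrogen.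

Compound 3 `CCCCCCCCCCCCCCCCO[C@@H]1O[C@H](CO)[C@@H](O)[C@H](O)[C@H]1O[C@@H]1O[C@@H](C)[C@H](OC(C)=O)[C@@H](O)[C@H]1OC(C)=O` is not yet measured. It differs from compound 2 by hydrogen in place of acetyl on an oxygen on a saturated carbon, the same kind of exchange as the measured step but run in the opposite direction, at a different oxygen of the second sugar. The step that bears on it is therefore an at least 1.5-fold lower number from compound 1 to compound 2 (0.18 log units; that floor lies within the scatter), whose size is known only as a floor, since compound 1 sits at the limit of > 39400 nM in this assay, at which 1 of the 2 values shown sits. A move back toward a higher number is the expectation, with a real chance that compound 3 also reports only a limit. Compound 3 is expected to give about 36000 nM, within a range of 18000 nM to 70000 nM. This estimate corresponds to an expected step of a 1.4-fold higher number from compound 2 to compound 3 (0.15 log units; within the scatter).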

Compound 3, half-maximal inhibitory concentration: > 39400 nM
Compound 3 ended at the assay's limit (the forecaster's own chance of this, stated with the estimate: 45%); middle value at least 1.0-fold (0.03 log units) from the limit.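

In this assay, acetoxy to hydroxy at this second oxygen gives an at least 1.5-fold higher number from compound 2 to compound 3 (0.18 log units; that floor lies within the scatter). Removing an acetyl from compound 2 has now been seen at two different oxygens of the second sugar, and both exchanges end at the limit, so the earlier result is no longer the record of a single oxygen. This does not establish a real loss of cytotoxicity at either oxygen or rank the two oxygens, and only a floor can be read for this step because the value of compound 3 is a limit and not a number, as is that of compound 1: the limit of > 39400 nM in this assay, at which 2 of the 3 values shown sit.

As far as these compounds go, how far compound 3 lies beyond its limit remains open, as does whether the remaining acetyl of compound 2 behaves in the same way when exchanged for hydrogen. Also open, from the compounds shown here alone, is whether a benzoyl ester or an amine at this oxygen would give a measurable number in this assay.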